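This account rests on a few compounds, and the source may have more. Where it says the series, first, only, none or still open, it means among the compounds named here.

Measured compounds:
compound 1 `CC(C(=O)NCc1ccc(C(F)(F)F)nc1NCc1ccc(Cl)cc1)c1ccc(NS(C)(=O)=O)c(F)c1` gives 65.7 nM
compound 2 `CC1CCCN1c1nc(C(F)(F)F)ccc1CNC(=O)[C@@H](C)c1ccc(NS(C)(=O)=O)c(F)c1` gives 0.3 nM
compound 3 `C[C@H](C(=O)NCc1ccc(C(F)(F)F)nc1N1CCC(c2ccccc2)CC1)c1ccc(NS(C)(=O)=O)c(F)c1` gives 0.3 nM

In a functional assay on CHO-K1 cells for antagonist activity at transient receptor potential cation channel subfamily V member 1 (Homo sapiens), read by FLIPR (on this read-out lower numbers stand for stronger inhibition and higher numbers for weaker inhibition), compound 1 stands highest of the three, far beyond the scatter from both compound 2 and compound 3. Going by the values given here, the two cyclic-amine compounds sit at the same value, and the single one-place step, no change at the digits printed from compound 2 to compound 3 (within the scatter), shows that exchanging one saturated ring amine for another on the aromatic carbon leaves the read-out unchanged.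

Compound 4 `CCCCOC1CCN(c2nc(C(F)(F)F)ccc2CNC(=O)C(C)c2ccc(NS(C)(=O)=O)c(F)c2)CC1` is compound 1 with a different group on the same aromatic carbon: a group of 11 heavy atoms (9 carbon, 1 nitrogen, 1 oxygen; one six-membered non-aromatic ring with 1 hetero atom) in place of a group of 9 heavy atoms (7 carbon, 1 nitrogen, 1 chlorine; one six-membered aromatic ring of carbon only), on an aromatic carbon. The entering group is a saturated ring amine of the same kind as those in compound 2 and compound 3, whereas compound 1 carries the open (4-chlorobenzyl)amino group. Among the compounds with values here, no measured step covers exactly this exchange; compound 1 and compound 2 also differ in stereochemistry, so only their two values can be compared, and they lie far apart.

Compound 4 is therefore expected to move well away from compound 1 toward the values of compound 2 and compound 3, the expected step being a 66-fold lower number from compound 1 to compound 4 (1.82 log units; beyond the scatter). The estimate for compound 4 in this assay is 1 nM, within a range of 0.2 nM to 6 nM.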

Compound 4, inhibition constant: 3.5 nM
Compound 4: the middle estimate sits 3.5-fold (0.54 log units) below what was measured; measured number inside the range.
By their numbers in this assay, from the lowest: compounds 2 and 3 (each within the scatter of the next); then compound 4; then compound 1.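

Going by these compounds alone, the step of a 19-fold lower number from compound 1 to compound 4 (1.27 log units; beyond the scatter) in this assay is the first reading at this position in which only the group on the aromatic carbon next to the ring nitrogen changes, since compound 1 and the earlier ring-amine compounds also differed in stereochemistry. It shows that replacing the open (4-chlorobenzyl)amino group with a group built on a six-membered non-aromatic ring with 1 hetero atom lowers the number well beyond the scatter on an otherwise unchanged structure. The exchange also removes the hydrogen-bond donor and the carbon-only aromatic ring while adding an oxygen, and no measurement available here explains why the number falls.

The compounds shown leave open which of these differences carries the step, a question that a plain diethylamino group or an unsubstituted piperidin-1-yl group at this position could help to separate. They also leave open how far the result depends on the butoxy chain, and a methoxy group or a hydroxyl group in its place would test that dependence directly.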